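The source may report more compounds than this note shows. Statements on the series, on what has been measured and on what is new or still open speak of the compounds shown alone.

Measured in a functional assay on A549 cells (Homo sapiens) for inhibition, read by sulforhodamine B assay, with a stated time of 72 h; a higher number here means a weaker inhibitor, a lower number a stronger inhibitor:
- compound 1 `C#Cc1cccc(Nc2ncnc3cc(OCCCCn4ccnc4[N+](=O)[O-])c(OC)cc23)c1`: 2210 nM
- compound 2 `COc1cc2c(Nc3cccc(Br)c3)ncnc2cc1OCCCn1ccnc1[N+](=O)[O-]`: 13500 nM

Compound 2, at 13500 nM, holds the higher of the two numbers, and compound 1 at 2210 nM lies lower by more than the usual scatter. Compound 3 `COc1cc2c(Nc3cccc(Br)c3)ncnc2cc1OCCCCn1ccnc1[N+](=O)[O-]` has not yet been measured. It differs from compound 2 by (2-nitro-1H-imidazol-1-yl)methyl in place of 2-nitro-1H-imidazol-1-yl on a saturated chain carbon, three bonds along the chain from an oxygen on an aromatic ring: (2-nitro-1H-imidazol-1-yl)methyl in place of 2-nitro-1H-imidazol-1-yl, on a saturated chain carbon, three bonds along the chain from an oxygen on an aromatic ring.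

Within the data shown here, no measured pair isolates this change. Compound 1, at 2210 nM, carries the same chain as compound 3, but it also differs from compound 2 elsewhere, so the gap between their values cannot be assigned to the chain alone. This gives only weak support for a move toward the value of compound 1. The step expected in this assay is modest and points toward a lower number, an estimated 2.1-fold lower number from compound 2 to compound 3 (0.32 log units; beyond the scatter). For compound 3 the expected value is 6500 nM, with an estimated range of 2200 nM to 16000 nM.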

Compound 3, half-maximal inhibitory concentration: 3090 nM
Estimate against measurement, compound 3: 2.1-fold (0.32 log units) above; the measured number falls inside the stated range.
By their numbers in this assay, from the lowest: compounds 1 and 3 (each within the scatter of the next); then compound 2.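

In this assay the chain change can now be read on its own: (2-nitro-1H-imidazol-1-yl)methyl in place of 2-nitro-1H-imidazol-1-yl on a saturated chain carbon, three bonds along the chain from an oxygen on an aromatic ring, gives a 4.4-fold lower number from compound 2 to compound 3 (0.64 log units; beyond the scatter) with the bromo group held constant, so this position does respond to the change in chain length. At the same chain, bromo in place of ethynyl on an aromatic carbon gives a 1.4-fold higher number from compound 1 to compound 3 (0.15 log units; within the scatter) and so does not separate the two groups at this chain length. The compounds shown come with no measurement that accounts for either step.

Going by these compounds, the chain step rests on a single pair carrying the bromo group, so whether it holds with the ethynyl group remains open. Also open, on these data alone, is how the number responds to a longer chain at this position, or to an amine or a carboxylic acid in place of the 2-nitro-1H-imidazol-1-yl group at the chain end.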